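Benzyl ester thiophene: moving the methyl on the phenyl ring

The source may hold more compounds than are shown below. What is called first, only, known or untested is meant among the compounds shown, and "the series" means these compounds.

Compound 3 `Cc1cccc(-c2csc(N)c2C(=O)OCc2ccccc2)c1` carries a benzyl ester on the shared core and gives 68% in an assay on isolated protein for inhibition of protein kinase C zeta type (Homo sapiens), with stated times of 1 h and 2.5 min, tested at 30 uM; on this read-out higher numbers stand for more inhibition at the one concentration tested (going by the name of the read-out) and lower numbers for less inhibition. Among the three measured compounds it has the lowest number. Compound 1 `CCOC(=O)c1c(-c2cccc(C)c2)csc1N` gives 77%; the step of a number 9 percentage points lower from compound 1 to compound 3 (within the scatter) lies within the scatter. Compound 2 `CCOC(=O)c1c(-c2ccc(C)cc2)csc1N` gives 80%, a number that stands above that of compound 3 by more than the scatter allows.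

Compound 4 `Cc1ccc(-c2csc(N)c2C(=O)OCc2ccccc2)cc1` differs from compound 3 in one place: 4-methylphenyl in place of 3-methylphenyl on an aromatic carbon. Going by the values given here, no measured step covers exactly this change on the benzyl ester. The closest guide is the pair of ethyl esters, compound 1 with the 3-methylphenyl and compound 2 with the 4-methylphenyl, whose two values lie close together. On that basis compound 4 is expected to show a step of a number 3 percentage points higher from compound 3 to compound 4 (within the scatter), within the scatter, in this assay. Compound 4 is therefore estimated at 71%, with a range from 60% to 82%.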

Compound 4, a percentage reported as inhibition, at one concentration (the size of the read-out at that concentration, not a potency): 60%
Compound 4: the middle estimate sits 11 percentage points above what was measured, and the stated range covers the measured number.
By their numbers in this assay, from the lowest: compounds 4, 3, 1 and 2 (each within the scatter of the next, the first and the last beyond it).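

On the benzyl ester, moving the methyl gives a number 8 percentage points lower from compound 3 to compound 4 (within the scatter), so in this assay 3-methylphenyl and 4-methylphenyl on this aromatic carbon cannot be told apart on this core either. Going by these compounds alone, the exchange of the ethyl ester for the benzyl ester now gives, with 4-methylphenyl in place, a step beyond the scatter for the first time: a number 20 percentage points lower from compound 2 to compound 4 (beyond the scatter). Set against the earlier step with 3-methylphenyl, however, this does not establish that the ester change depends on where the methyl sits: the same change on two cores in this assay, a number 9 percentage points lower (within the scatter) from compound 1 to compound 3 and a number 20 percentage points lower (beyond the scatter) from compound 2 to compound 4, 11 percentage points apart, within the scatter of two such steps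

The compounds shown leave open how a carboxylic acid or a primary amide in place of the ester would read out in this assay. They also leave open what an unsubstituted phenyl or a methoxy group in place of the methyl on the phenyl ring would give.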